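Notes on the sulfonyl aryl group of compound 1

The compounds below may be only part of what the source reports. "The series", "measured", "known", "first", "only" and "open" are said of these compounds alone.

Measured so far:
compound 1, `CC1CCN(C2CCN(S(=O)(=O)c3ccc(C#N)cc3)CC2)CC1`, 2800 nM
compound 2, `CCCOc1ccc(S(=O)(=O)N2CCC(N3CCC(C)CC3)CC2)cc1`, 452 nM
compound 3, `CCCCOc1ccc(S(=O)(=O)N2CCC(N3CCC(C)CC3)CC2)cc1`, 2300 nM

In a functional assay on DLD-1 cells (Homo sapiens) for antiproliferative activity, read by CellTiter-Glo, with a stated time of 72 h (on this read-out higher numbers stand for weaker inhibition and lower numbers for stronger inhibition), compound 1 gives the highest of the three numbers; compound 3 sits within the scatter of it, a 1.2-fold lower number from compound 1 to compound 3 (0.09 log units; within the scatter), while compound 2 lies clearly lower, a 6.2-fold lower number from compound 1 to compound 2 (0.79 log units; beyond the scatter). Compound 4, `CC1CCN(C2CCN(S(=O)(=O)c3ccc(Cl)cc3Cl)CC2)CC1`, differs from compound 1 by 2,4-dichlorophenyl in place of 4-cyanophenyl on a sulfonyl sulfur. Going by the values given here, no measured step swaps in a halogenated ring, so only the two cyano replacements bear on it: one modest lowering, one flat. A change of this kind is therefore expected to move this assay little, with at most a modest drop, a 2.2-fold lower number from compound 1 to compound 4 (0.33 log units; beyond the scatter). For compound 4 the expected value is 1300 nM, range 400 nM to 4000 nM.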

Compound 4, half-maximal inhibitory concentration: 1 nM
The estimate for compound 4 lay 1300-fold (3.11 log units) above the measured number, outside the stated range (below it).
By their numbers in this assay, from the lowest: compound 4; then compound 2; then compounds 3 and 1 (each within the scatter of the next).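

Going by these compounds alone, the sulfonyl aryl group of compound 1 proves far more sensitive in this assay than the alkoxy replacements indicated: 2,4-dichlorophenyl in place of 4-cyanophenyl on a sulfonyl sulfur gives a 2800-fold lower number from compound 1 to compound 4 (3.45 log units; beyond the scatter) and is a large step, whereas the earlier steps were modest or flat. Changes at this position can therefore shift the number far more than those steps showed. No data at hand account for the size of this step.

On these data alone, it remains open whether both chlorines are needed, which 4-chlorophenyl and 2-chlorophenyl would separate. As far as these compounds go, whether the effect is specific to chlorine also remains open, and 2,4-difluorophenyl and 2,4-dibromophenyl would address that.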